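Piperidin-1-yl to 4-Methylpiperazin-1-yl on a Carbonyl Carbon

A few compounds are considered here, and "the series" means these few. Any claim that something is new, unique, unknown or untested is made for them only; others in the source may bear on it.

Three compounds have been measured in a functional assay on the whole organism with Rattus norvegicus as the target, read by paw edema, with a stated time of 3 h, at a dose of 100 mg/kg by the oral route; a higher number here means more inhibition at the dose given (going by the name of the read-out), a lower number less inhibition:
compound 1 `Cc1ccc(-c2nc3ccccc3n2CCN(C)C)nc1` gives 12%;
compound 2 `Cc1ccc(-c2nc3ccccc3n2CC(=O)N2CCCC2)nc1` gives 14%;
compound 3 `Cc1ccc(-c2nc3ccccc3n2CC(=O)N2CCCCC2)nc1` gives 2%.

Compound 3 stands lowest of the three: compound 1 is higher but within the scatter, while compound 2 is higher beyond it, as a number 12 percentage points lower from compound 2 to compound 3 (beyond the scatter) shows. Compound 4 `Cc1ccc(-c2nc3ccccc3n2CC(=O)N2CCN(C)CC2)nc1` differs from compound 3 only at the carbonyl carbon: 4-methylpiperazin-1-yl in place of piperidin-1-yl on a carbonyl carbon. Among the measured compounds shown here, the one measured step at that position, a number 12 percentage points lower from compound 2 to compound 3 (beyond the scatter), was modest, and no measured step introduces a 4-methylpiperazin-1-yl group. A small step is therefore expected, a number 7 percentage points higher from compound 3 to compound 4 (within the scatter), without confidence in its direction. Compound 4 is estimated to give 9%, ranging from 0% to 22%.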

Compound 4, a percentage reported as inhibition, in the whole organism at one dose (the size of the read-out at that dose, not a potency): 11%
Beside the measured number, compound 4's estimate is 2 percentage points below it, and the stated range covers the measured number.
By their numbers in this assay, from the lowest: compounds 3, 4, 1 and 2 (each within the scatter of the next, the first and the last beyond it).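

In this assay, 4-methylpiperazin-1-yl on the carbonyl carbon gives a number 9 percentage points higher from compound 3 to compound 4 (within the scatter), and a number 3 percentage points lower from compound 2 to compound 4 (within the scatter). Compound 4 therefore lies within the scatter of both compound 2 and compound 3, even though those two lie beyond the scatter of each other, so the new group cannot be ranked against either ring it replaces. Nothing available explains these steps.

Still open, going by these compounds, is how morpholin-4-yl or an open-chain dimethylamino group on the same carbonyl carbon would compare.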